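The compounds below may be only part of what the source reports. "The series", "measured", "known", "first", "only" and "open" are said of these compounds alone.

Measured so far in a functional assay on PANC-1 cells (Homo sapiens) for antiproliferative activity; on this read-out higher numbers stand for weaker inhibition and lower numbers for stronger inhibition:
compound 1, `CC[C@H](C)[C@H]1C(=O)N[C@H](Cc2cc(Cl)c(O)c(Cl)c2)C(=O)N[C@@H](C(C)(C)O)C(=O)O[C@H](c2ccccc2)[C@H](C)/C=C/C=C(\C)[C@H](OC)C[C@H]2O[C@]2(C)C(=O)N1C`: > 200 nM
compound 2, `CC[C@H](C)[C@H]1C(=O)N[C@H](Cc2cc(Cl)c(O)c(Cl)c2)C(=O)N[C@@H](C(C)C)C(=O)O[C@H](c2ccccc2)[C@H](C)/C=C/C=C(\C)[C@H](OC)C[C@@H]2O[C@@]2(C)C(=O)N1C`: 15.5 nM

Compound 1 gives only a limit in this assay, (the limit of > 200 nM in this assay, at which 1 of the 2 values shown sits), and not a number. Within the data shown here, compound 2 gives the single numerical value in the set, 15.5 nM, so it is the only compound that can serve as a point of reference.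

Compound 3, `CC[C@H](C)[C@H]1C(=O)N[C@H](Cc2cc(Cl)c(O)c(Cl)c2)C(=O)N[C@@H](C(C)(C)O)C(=O)O[C@H](c2ccccc2)[C@H](C)/C=C/C=C(\C)[C@H](OC)C[C@@H]2O[C@@]2(C)C(=O)N1C`, has not been measured. It differs from compound 2 in one place: hydroxy in place of hydrogen on a saturated chain carbon bound to two saturated chain carbons and a saturated ring carbon. Among the measured compounds shown here, no step between two measured compounds is available for this change, so its size is not known from the set. For compound 3 a loss in this assay is expected, estimated as a 2.6-fold higher number from compound 2 to compound 3 (0.41 log units; beyond the scatter), and on the present numbers a result near the reporting limit cannot be ruled out. Compound 3 is accordingly estimated at 40 nM, with a range from 12 nM to 150 nM.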

Compound 3, half-maximal inhibitory concentration: 12.2 nM
Compound 3: the middle estimate sits 3.3-fold (0.52 log units) above what was measured; measured number inside the range.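

In this assay, hydroxy in place of hydrogen on a saturated chain carbon bound to two saturated chain carbons and a saturated ring carbon gives a 1.3-fold lower number from compound 2 to compound 3 (0.10 log units; within the scatter), so isopropyl and 1-hydroxy-1-methylethyl cannot be told apart here. Compound 1 carries a limit, > 200 nM, and not a number. With 1-hydroxy-1-methylethyl present in both compounds, an at least 16-fold lower number from compound 1 to compound 3 (1.21 log units; beyond the scatter), and this large step can be put down to configuration and not to the hydroxy group because of: the fact that compounds 1 and 3 differ only in the configuration as drawn

From the compounds shown here alone, both stereocentres at saturated ring carbons differ together, so the share of each in this step stays open. Going by these compounds, whether an amine, a methoxy group or a longer chain on the same carbon would match hydroxy in this assay also stays open.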